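Adding a chloro group to compound 3

A few compounds are considered here, and "the series" means these few. Any claim that something is new, unique, unknown or untested is made for them only; others in the source may bear on it.

Going by the values given here, in a functional assay on MDA-MB-231 cells (Homo sapiens) for cytotoxicity, read by MTT assay, with a stated time of 72 h (a lower number here means a stronger inhibitor, a higher number a weaker inhibitor), compound 3 (`CC1CCN(Cc2ccc3nc(NC(=O)N/N=C/c4cn(Cc5ccccc5)c5ccccc45)sc3c2)CC1`) gives 2850 nM, the highest of the three numbers so far. Compound 1 (`Cc1ccc(Cn2cc(/C=N/NC(=O)Nc3nc4ccc(CN5CCC(C)CC5)cc4s3)c3ccccc32)cc1`) gives 1140 nM and compound 2 (`CN(C)Cc1ccc2nc(NC(=O)N/N=C/c3cn(Cc4ccc(Cl)cc4)c4ccccc34)sc2c1`) gives 880 nM.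

Compound 4 (`CC1CCN(Cc2ccc3nc(NC(=O)N/N=C/c4cn(Cc5ccc(Cl)cc5)c5ccccc45)sc3c2)CC1`) changes compound 3 in one place: chloro in place of hydrogen on an aromatic carbon. This puts chloro in place of hydrogen on an aromatic carbon, para to a large group.

Among the compounds with values here, only one measured step touches that same carbon, and it is modest: a 2.5-fold higher number from compound 1 to compound 3 (0.40 log units; beyond the scatter). Compound 1 has a methyl there, so that step shows a lower number with a methyl than with hydrogen. Compound 2 already carries the 4-chlorobenzyl group, but it also differs elsewhere, so its 880 nM is only a loose guide.

Together these suggest a modest move towards a lower number, though no measured pair isolates the chloro group. The expected change is a 2.6-fold lower number from compound 3 to compound 4 (0.41 log units; beyond the scatter). Compound 4 is estimated at 1100 nM, within an expected range of 500 nM to 2400 nM.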

Compound 4, half-maximal inhibitory concentration: 2850 nM
Estimate against measurement, compound 4: 2.6-fold (0.41 log units) below; measured number outside the range, above it.
By their numbers in this assay, from the lowest: compounds 2 and 1 (each within the scatter of the next); then compounds 3 and 4 (each within the scatter of the next).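

In this assay the chloro group gives no change at the digits printed from compound 3 to compound 4 (within the scatter) and so cannot be told apart from hydrogen on this aromatic carbon, while methyl on the same carbon does differ from chloro, with a 2.5-fold higher number from compound 1 to compound 4 (0.40 log units; beyond the scatter) on going from methyl to chloro. With the 4-chlorobenzyl group held fixed, the change at the other end of the molecule, from dimethylamino to 4-methylpiperidin-1-yl, gives a 3.2-fold higher number from compound 2 to compound 4 (0.51 log units; beyond the scatter) and shows that the chloro group alone does not bring a low number. Nothing measured here explains why methyl and chloro differ at this position.

On these data alone, it remains open whether a methoxy group or a fluorine on this carbon would behave like methyl or like chloro. Also open, as far as these compounds go, is whether hydrogen in place of chloro would leave compound 2 just as unchanged.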